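Antiproliferative limits across two cores with nitro-to-fluoro exchange

The source may report more compounds than this note shows. Statements on the series, on what has been measured and on what is new or still open speak of the compounds shown alone.

Measured compounds:
- compound 1 `COc1ccc(-c2cc(=O)c3c(OC)cc(OC)cc3n2S(=O)(=O)c2ccc([N+](=O)[O-])cc2)cc1`: in an ADME assay on BJ cells (Homo sapiens) for antiproliferative activity, with a stated time of 72 h (a lower number here means that less compound is needed, a higher number that more compound is needed for the effect), compound 1 gives only a limit, > 29300 nM.
- compound 2 `COc1ccc(-c2cc(=O)c3c(OC)cc(OC)cc3n2S(=O)(=O)c2ccc(F)cc2)cc1`: in this assay compound 2 gives only a limit, > 65500 nM.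
- compound 3 `COc1cc(OC)c2c(=O)cc(C(=O)Nc3ccc(Oc4ccc([N+](=O)[O-])cc4)cc3)[nH]c2c1`: in this assay compound 3 gives only a limit, > 22900 nM.

The change from compound 1 to compound 2 is fluoro in place of nitro on an aromatic carbon, and the step it made is a step that the two limits leave unreadable from compound 1 to compound 2. The difference between the core of compound 1 and the core of compound 3 is not broken down here. Compound 4 `COc1cc(OC)c2c(=O)cc(C(=O)Nc3ccc(Oc4ccc(F)cc4)cc3)[nH]c2c1` carries the same change relative to compound 3, (fluoro in place of nitro on an aromatic carbon); both places read the same word for word.

For compound 4 a step that the limit leaves unreadable from compound 3 to compound 4 is expected, resting on the fact that compound 1, compound 2 and compound 3 all sit at limits (the limit of > 22900 nM in this assay, at which 1 of the 3 values shown sits, (the limit of > 29300 nM in this assay, at which 1 of the 3 values shown sits), (the limit of > 65500 nM in this assay, at which 1 of the 3 values shown sits)). Compound 4 is therefore estimated at 50000 nM, most likely reported as a limit again, with a range of 10000 nM to 250000 nM.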

Compound 4, half-maximal effective concentration: > 50000 nM
Compound 4: only a limit was reported; the forecaster's own chance of this, stated with the estimate: 85%; the middle value lies on the limit itself.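

In this assay compound 4 gives only a limit, > 50000 nM. Going by these compounds alone, compound 3 also gives only a limit, > 22900 nM, and no step from compound 3 to compound 4 can be read. The compounds shown leave open whether exchanging nitro for fluoro changes the effective concentration in either core.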